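A few compounds are considered here, and "the series" means these few. Any claim that something is new, unique, unknown or untested is made for them only; others in the source may bear on it.

Working notes on the series in a functional assay on DU-145 cells (Homo sapiens) for inhibition, read by trypan blue exclusion, with a stated time of 96 h; on this read-out higher numbers stand for weaker inhibition of growth and lower numbers for stronger inhibition of growth.

Compound 1 `CN(C)c1ccc(/C=C(/SCc2ccccc2Cl)C(=O)c2ccc(Cl)cc2)cc1` reaches only the limit > 100000 nM in this assay. Compound 3 `Cc1ccc(CS/C(=C/c2ccc(N(C)C)cc2)C(=O)c2ccc(Cl)cc2)cc1` likewise reaches only the limit > 100000 nM in this assay. The two share a core and differ by 4-methylphenyl in place of 2-chlorophenyl on a saturated chain carbon bound to a sulfur; the step that the two limits leave unreadable from compound 1 to compound 3 cannot be sized because the limit of > 100000 nM in this assay, at which 2 of the 3 values shown sit, covers both ends of it.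

Within the data shown here, compound 2 `O=C(O)c1ccc(C(=O)/C(=C\c2ccc(F)c([N+](=O)[O-])c2)SCc2ccccc2Cl)cc1` gives 1000 nM in this assay, the only number in the set. How the core of compound 2 differs from the core of compound 1 is not broken down here.

Compound 4 `Cc1ccc(CS/C(=C/c2ccc(F)c([N+](=O)[O-])c2)C(=O)c2ccc(C(=O)O)cc2)cc1` is not yet measured in this assay. It differs from compound 2 by 4-methylphenyl in place of 2-chlorophenyl on a saturated chain carbon bound to a sulfur, the same change as that from compound 1 to compound 3.

That earlier step gives no readable size, so the expectation for compound 4 rests mainly on compound 2 at 1000 nM and on the exchange of one benzyl group for another of equal heavy-atom count. The step from compound 2 to compound 4 is expected to be small, about a 1.5-fold higher number from compound 2 to compound 4 (0.18 log units; within the scatter). Compound 4 is estimated at 1500 nM in this assay, within 400 nM to 6000 nM.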

Compound 4, concentration for 50% growth inhibition in the DU-145 assay: 1000 nM
Compound 4: the middle estimate sits 1.5-fold (0.18 log units) above what was measured, within the range that was stated.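

In the DU-145 assay, compound 2 gives 1000 nM and compound 4 gives 1000 nM; 4-methylphenyl in place of 2-chlorophenyl on a saturated chain carbon bound to a sulfur gives no change at the digits printed from compound 2 to compound 4 (within the scatter), so on the core of compound 2 the two groups read alike. The same exchange cannot be read on the core of compound 1 in the DU-145 assay, nor on the core of compound 2 in a physicochemical assay for solubility (on this read-out higher numbers stand for higher solubility and lower numbers for lower solubility), as both ends of each of these pairs are limits and not numbers. In the physicochemical assay compound 2 gives the limit < 1000 ug/mL. In the physicochemical assay compound 4 also gives a limit, < 1000 ug/mL. The result thus rests on a single readable pair and on one core, and it does not show that the exchange behaves the same way on another core.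

Open is whether 2-methylphenyl or 4-chlorophenyl would read like the two groups shown, which would separate the kind of group on the ring from its place. Also open, on these data alone, is how far the benzyl position tolerates something else, such as a longer chain or an amine on the chain carbon bound to the sulfur.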